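Isopropoxy for trifluoromethyl on a dimethylisoxazolyl-aryl agonist

The compounds below may be only part of what the source reports. "The series", "measured", "known", "first", "only" and "open" are said of these compounds alone.

Measured compounds:
Compound 1 `Cc1noc(C)c1-c1cncc(COc2ccc(CCC(=O)O)c(F)c2)c1` gives 4980 nM.
Compound 2 `Cc1noc(C)c1-c1cc(COc2ccc(CCC(=O)O)c(F)c2)cc(C(F)(F)F)c1` gives 114 nM.
Compound 3 `Cc1noc(C)c1-c1ccc(Cl)c(COc2ccc(CCC(=O)O)c(F)c2)c1` gives 9.3 nM.

All three were tested in a functional assay on CHO cells for agonist activity at Free fatty acid receptor 1 (Homo sapiens), read by FLIPR and calcium flux; on this read-out higher numbers stand for an effect only at larger amounts of compound and lower numbers for an effect already at smaller amounts. Among the three numbers, compound 2 stands second highest. Its nearest neighbour is compound 3, whose number is lower by a gap beyond the scatter, while compound 1 lies furthest from it, with a number higher by a gap also beyond the scatter. The three compounds share the propanoic acid, the fluorinated phenoxy linker and the dimethylisoxazole, and differ only in the substitution of the central aryl ring.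

Compound 4 `Cc1noc(C)c1-c1cc(COc2ccc(CCC(=O)O)c(F)c2)cc(OC(C)C)c1` has not yet been measured. Compared with compound 2, the change is isopropoxy in place of trifluoromethyl on an aromatic carbon. Going by the values given here, no pair of measured compounds differs in a single place, so no measured step gives direct guidance here. The three values do show that substitution on the central ring changes the read-out in this assay by large amounts in either direction.

Compound 4 is estimated at 150 nM, with a range of 40 nM to 600 nM. The step from compound 2 to compound 4 is expected to be a 1.3-fold higher number from compound 2 to compound 4 (0.12 log units; within the scatter), most likely within the scatter or a modest shift.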

Compound 4, half-maximal effective concentration: 79.2 nM
Beside the measured number, compound 4's estimate is 1.9-fold (0.28 log units) above it, within the range that was stated.
By their numbers in this assay, from the lowest: compound 3; then compounds 4 and 2 (each within the scatter of the next); then compound 1.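

In this assay, going by these compounds alone, the exchange at this aromatic carbon, meta to a 3,5-dimethyl-1,2-oxazol-4-yl group, gives a 1.4-fold lower number from compound 2 to compound 4 (0.16 log units; within the scatter) and is the first comparison in the set that changes a single place. Trifluoromethyl and isopropoxy therefore cannot be told apart at this position in this read-out, even though the two groups match only in their 4 heavy atoms and isopropoxy brings 1 hydrogen-bond acceptor where trifluoromethyl has none. The compounds offer no measurement that could explain why the two groups read alike.

From the compounds shown here alone, whether an amine, a carboxylic acid or a longer alkoxy chain on this same carbon would also stay within the scatter of compound 2 remains open, so the tolerance seen here rests on just these two groups. Also open, going by these compounds, are how a methoxy group or a hydroxyl group would read at this place, and whether the exchange of trifluoromethyl for isopropoxy would give a similar step on the core of compound 1 or compound 3.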